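The source may hold more compounds than are shown below. What is called first, only, known or untested is meant among the compounds shown, and "the series" means these compounds.

Compound 1 `O=C(N1CCOCC1)n1cc(-c2ccc3cn[nH]c3c2)ccc1=O` stands at a limit rather than a number in an assay for inhibition of MAP kinase-interacting serine/threonine-protein kinase 1 (Homo sapiens), read by luminescence and ADP-Glo, with a stated time of 2 h; on this read-out lower numbers stand for stronger inhibition and higher numbers for weaker inhibition: compound 1 gives > 2000 nM, which is the limit of > 2000 nM in this assay, at which 1 of the 3 values shown sits. Two further compounds have measured numbers in this assay. Compound 2 `Nc1n[nH]c2cc(-c3ccc(=O)n(Cc4cccc(F)c4)c3)ccc12` gives 19 nM, and compound 3 `Nc1n[nH]c2cc(-c3ccc(=O)n(Cc4cccc(C(F)(F)F)c4)c3)ccc12` gives 56 nM. Within the data shown here, the one single change among the measured compounds, a 2.9-fold higher number from compound 2 to compound 3 (0.47 log units; beyond the scatter), is a modest step.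

Compound 4 `O=c1ccc(-c2ccc3cn[nH]c3c2)cn1Cc1ccccc1F` is not yet measured. It differs from compound 1 by 2-fluorobenzyl in place of (morpholin-4-yl)carbonyl on an aromatic nitrogen. Compound 2 and compound 3 also carry a benzyl group, but they differ from compound 4 in more than that one place. Among the measured compounds shown here, the change from compound 1 to compound 4 is therefore not described by the single measured step; that step, a 2.9-fold higher number from compound 2 to compound 3 (0.47 log units; beyond the scatter), only shows that fluoro and trifluoromethyl on the benzyl group give numbers of the same order. For the measured compounds named here, no measured step covers the exchange of a morpholinylcarbonyl for a benzyl group. The expectation of a lower number for compound 4 rests on compound 2 with 19 nM and compound 3 with 56 nM, both benzyl compounds with measured numbers. On that basis a step toward a lower number is expected, an at least 6.6-fold lower number from compound 1 to compound 4 (0.82 log units; beyond the scatter). Compound 4 is estimated at 300 nM in this assay, with a range from 60 nM to 1500 nM.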

Compound 4, half-maximal inhibitory concentration: 47 nM
The estimate for compound 4 lay 6.4-fold (0.81 log units) above the measured number; the whole stated range lies above it.
By their numbers in this assay, from the lowest: compound 2; then compounds 4 and 3 (each within the scatter of the next). At a limit, above all of these: compound 1.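

Before this result, the only step among the measured compounds was a change on the benzyl ring, so none showed what happens when one kind of group on the aromatic nitrogen is exchanged for a very different one. In this assay, placing 2-fluorobenzyl there in place of (morpholin-4-yl)carbonyl gives an at least 42-fold lower number from compound 1 to compound 4 (1.62 log units; beyond the scatter), a large step, which shows that the choice of group at this nitrogen matters greatly for the number read out, even though both groups have the same count of heavy atoms. Only the lower bound of this step is known, since compound 1 stands at a limit and not at a measured number: the limit of > 2000 nM in this assay, at which 1 of the 4 values shown sits.

The compounds shown leave open whether the aromatic ring of the benzyl group is what matters or whether removing the carbonyl-linked morpholine is enough, a question that a plain methyl group or a longer alkyl chain on the same nitrogen could help to answer. They also leave open what the fluorine on the benzyl ring of compound 4 contributes, which could be tested with an unsubstituted benzyl group or one carrying a methoxy group or an amine.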